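This account rests on a few compounds, and the source may have more. Where it says the series, first, only, none or still open, it means among the compounds named here.

Measured compounds:
- compound 2 `COC(=O)/C=C/c1cccc(N(Cc2ccc(/C=C/c3c(C)cc(C)cc3C)cc2)C(=O)C(C)C)c1`: 149 nM
- compound 3 `COC(=O)/C=C/c1cccc(N(Cc2ccc(/C=C/c3c(C)cc(C)cc3C)cc2)C(=O)NC(C)C)c1`: 431 nM
- compound 1 `COC(=O)/C=C/c1cccc(N(Cc2ccc(/C=C/c3cccc(C(F)(F)F)c3)cc2)C(=O)NC(C)C)c1`: 932 nM

In an assay on isolated protein with Bile acid receptor (Homo sapiens) as the target (on this read-out higher numbers stand for an effect only at larger amounts of compound and lower numbers for an effect already at smaller amounts), compound 2 holds the lowest number of the three. Its nearest neighbour is compound 3, reached by a 2.9-fold higher number from compound 2 to compound 3 (0.46 log units; beyond the scatter), which is isopropylamino in place of isopropyl on the carbonyl carbon. For the measured compounds named here, compound 1 lies furthest away; the two values of compound 1 and compound 2 differ in both the amide end and the aryl end, so no single step connects them.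

Compound 4 `CCOc1cccc(-c2ccc(CN(C(=O)C(C)C)c3cccc(/C=C/C(=O)OC)c3)cc2)c1` is the next candidate. It differs from compound 2 by 3-ethoxyphenyl in place of 2-(2,4,6-trimethylphenyl)ethenyl on an aromatic carbon. Going by the values given here, the only measured step touching that end of the molecule is a 2.2-fold lower number from compound 1 to compound 3 (0.33 log units; beyond the scatter), a modest change in this assay when one ring was exchanged for another while the ethenyl chain was kept. Among the compounds with values here, compound 4 removes the chain altogether and puts a ring directly onto the aromatic carbon; no measured pair covers such a change, so the direction is uncertain and the size could exceed that of the ring swap alone. For compound 4 a step of a 4.0-fold higher number from compound 2 to compound 4 (0.60 log units; beyond the scatter) is expected, leaning toward a higher number than compound 2. The estimate for compound 4 in this assay is 600 nM, with a range from 120 nM to 3000 nM.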

Compound 4, half-maximal effective concentration: 173 nM
Estimate against measurement, compound 4: 3.5-fold (0.54 log units) above; the range from low to high includes it.
By their numbers in this assay, from the lowest: compounds 2 and 4 (each within the scatter of the next); then compound 3; then compound 1.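

In this assay the exchange at this aromatic carbon, para to a large group, gives a 1.2-fold higher number from compound 2 to compound 4 (0.06 log units; within the scatter), so the 2-(2,4,6-trimethylphenyl)ethenyl and 3-ethoxyphenyl groups cannot be told apart on this read-out. The earlier change at this end, a 2.2-fold lower number from compound 1 to compound 3 (0.33 log units; beyond the scatter), kept the ethenyl chain and exchanged only the ring; the new pair shows that, with isopropyl on the carbonyl carbon, the value stays within the scatter even when the double bond outside the aromatic rings is gone and the entering ring carries an ethoxy group. No evidence on hand bears on this result.

On these data alone, it remains open whether the same exchange holds with isopropylamino on the carbonyl carbon, and whether the ethoxy group itself matters, which a plain phenyl, a 3-methoxyphenyl or a 3-hydroxyphenyl at the same place would test. As far as these compounds go, the role of the methyl ester also stays open, as the carboxylic acid in its place would show for this biaryl-free and ring-linked pair of end groups alike.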